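Chloro for Isopropyl on the Aryl Ether of Compound 3

A few compounds are considered here, and "the series" means these few. Any claim that something is new, unique, unknown or untested is made for them only; others in the source may bear on it.

Compound 3 `CC(C)c1ccc(OCC2[C@H]3CN(Cc4nc5ccccc5n4C)C[C@@H]23)cc1` stands highest of the three numbers in an in vitro assay on HEK293 cells with metabotropic glutamate receptor 2 (Rattus norvegicus) as the target, read by FLIPR, in the presence of a further agent that is not named here; on this read-out lower numbers stand for an effect already at smaller amounts and higher numbers for an effect only at larger amounts of compound; compound 3 gives 26 nM. Compound 1 `Cn1c(CN2C[C@@H]3C(COc4ccccc4)[C@@H]3C2)nc2ccccc21` gives 24 nM. In this assay there is a 1.1-fold higher number from compound 1 to compound 3 (0.03 log units; within the scatter). Compound 2 `Cn1c(CN2C[C@@H]3C(COc4cc(F)ccc4F)[C@@H]3C2)nc2ccccc21` gives 7 nM. There is a 3.7-fold higher number from compound 2 to compound 3 (0.57 log units; beyond the scatter). Compound 4 `Cn1c(CN2C[C@@H]3C(COc4ccc(Cl)cc4)[C@@H]3C2)nc2ccccc21` differs from compound 3 by chloro in place of isopropyl on an aromatic carbon. Going by the values given here, two measured steps bear on this: a 1.1-fold higher number from compound 1 to compound 3 (0.03 log units; within the scatter), where isopropyl in place of hydrogen left the number unchanged, and a 3.4-fold lower number from compound 1 to compound 2 (0.54 log units; beyond the scatter), where fluorines on the ring lowered it. Taking the isopropyl away should change little; a halogen on the ring may lower the number somewhat. The expected step is a 1.7-fold lower number from compound 3 to compound 4 (0.24 log units; within the scatter). Compound 4 is estimated at 15 nM, with a range from 6 nM to 35 nM.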

Compound 4, half-maximal effective concentration: 26 nM
Estimate against measurement, compound 4: 1.7-fold (0.24 log units) below, within the range that was stated.
By their numbers in this assay, from the lowest: compound 2; then compounds 1, 3 and 4 (each within the scatter of the next).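

In this assay, this aromatic carbon para to a large group does not tell the groups apart, with no change at the digits printed from compound 3 to compound 4 (within the scatter) and with a 1.1-fold higher number from compound 1 to compound 4 (0.03 log units; within the scatter) for chloro against hydrogen. A single chloro thus does not bring the lower number seen with the 2,5-difluorophenyl ring, as a 3.7-fold higher number from compound 2 to compound 4 (0.57 log units; beyond the scatter) shows, so a halogen on the ring is not enough by itself. No evidence at hand accounts for this result. Open, from the compounds shown here alone, is whether an amine or a carboxylic acid on this carbon would move the number, and whether a 2,5-dichlorophenyl ring would match compound 2.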